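The compounds below may be only part of what the source reports. "The series", "measured", "known", "first", "only" and "open" are said of these compounds alone.

Working notes on the alpha-ketooxazole series.

Of the compounds shown here, two carry numbers so far. Compound 1, `O=C(CCCCCCc1ccccc1)c1ncc(-c2ccccc2F)o1`, gives in an assay (Rattus norvegicus) for inhibition of Fatty-acid amide hydrolase 1 (Homo sapiens) (a higher number here means a weaker inhibitor, a lower number a stronger inhibitor), a value of 110 nM. Compound 2, `Cc1ccnc(-c2cnc(C(=O)CCCCCCc3ccccc3)o2)c1`, gives in this assay a value of 0.6 nM. Going by the values given here, the single one-place step connecting them, a 180-fold lower number from compound 1 to compound 2 (2.26 log units; beyond the scatter), is the only measured step in the set. Compound 2 therefore stands with the lowest of the two numbers, and its nearest neighbour is compound 1 at a far higher number.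

Compound 3, `O=C(CCCCCCc1ccccc1)c1ncc(C(=O)N2CCSCC2)o1`, is the next compound to be measured in this assay. Its difference from compound 2 is (thiomorpholin-4-yl)carbonyl in place of 4-methylpyridin-2-yl on an aromatic carbon. Among the compounds with values here, no measured step covers this exchange directly; the only step available, a 180-fold lower number from compound 1 to compound 2 (2.26 log units; beyond the scatter), shows that the group at this position of the shared core moves the number by a large amount. Since the group that produced that gain is now removed and a different kind of group enters, the expected direction is an increase in the number, of uncertain size.

The estimate for compound 3 in this assay is 20 nM, with a range from 2 nM to 200 nM, which would correspond to an expected step of a 33-fold higher number from compound 2 to compound 3 (1.52 log units; beyond the scatter).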

Compound 3, inhibition constant: 10 nM
The estimate for compound 3 lay 2.0-fold (0.30 log units) above the measured number; low and high end bracket the measured number.
By their numbers in this assay, from the lowest: compound 2; then compound 3; then compound 1.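

In this assay, the place next to the ring oxygen does not depend on an aromatic ring: (thiomorpholin-4-yl)carbonyl, with its six-membered non-aromatic ring, gives an 11-fold lower number from compound 1 to compound 3 (1.04 log units; beyond the scatter) in the exchange for 2-fluorophenyl. The same group does not match 4-methylpyridin-2-yl, with a 17-fold higher number from compound 2 to compound 3 (1.22 log units; beyond the scatter), so the three groups at this one place give three separate levels, with the non-aromatic group in the middle and the two aromatic groups at either end. Nothing measured here explains this order.

The compounds shown do not separate the contribution of the carbonyl from that of the thiomorpholine ring and its sulfur, a question that a morpholin-4-yl amide, a piperidin-1-yl amide or a carboxylic acid at the same place would bear on. On these data alone, it also remains open whether the ring nitrogen or the methyl group of 4-methylpyridin-2-yl goes with the low number of compound 2, which an unsubstituted pyridin-2-yl or a plain phenyl would help to settle.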